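Linker shortening from compound 2 to compound 4

The source may hold more compounds than are shown below. What is called first, only, known or untested is meant among the compounds shown, and "the series" means these compounds.

Measured so far:
compound 1, `CC(C)CC(=O)c1ccc(OCCCCOc2ccccc2)c(Br)c1O`, gives 1500 nM in a functional assay for binding affinity to metabotropic glutamate receptor 2 (Homo sapiens), read by GTPgammaS binding; a lower number here means that less compound is needed, a higher number that more compound is needed for the effect.
compound 2, `Cc1c(OCc2cccc(CSc3ccncc3)c2)ccc(C(=O)CC(C)C)c1O`, gives 819 nM in this assay.
compound 3, `Cc1c(OCc2ccc(CSc3ccncc3)cc2)ccc(C(=O)CC(C)C)c1O`, gives 770 nM in this assay.

Compound 2 stands second highest of the three numbers. Its nearest neighbour is compound 3, within the scatter, and compound 1 is also within the scatter of compound 2, so no order among the three can be read from these numbers.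

Compound 4, `Cc1c(OCc2cccc(Sc3ccncc3)c2)ccc(C(=O)CC(C)C)c1O`, differs from compound 2 by (pyridin-4-yl)sulfanyl in place of ((pyridin-4-yl)sulfanyl)methyl on an aromatic carbon. Going by the values given here, no measured pair shows this change, so the effect of shortening the link is unknown. The step is expected to be small and not beyond the scatter, in either direction; the expected step from compound 2 to compound 4 is a 1.1-fold higher number from compound 2 to compound 4 (0.04 log units; within the scatter). Compound 4 is therefore estimated at 900 nM in this assay, with a range from 300 nM to 2700 nM.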

Compound 4, half-maximal effective concentration: 890 nM
For compound 4 the middle estimate is 1.0-fold (0.00 log units) above the measured one; measured number inside the range.
By their numbers in this assay, from the lowest: compounds 3, 2, 4 and 1 (each within the scatter of the next).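

Going by these compounds alone, this is the first pair that differs in one place: on an aromatic carbon, meta to a large group, (pyridin-4-yl)sulfanyl in place of ((pyridin-4-yl)sulfanyl)methyl gives, in this assay, a 1.1-fold higher number from compound 2 to compound 4 (0.04 log units; within the scatter), so at this position the shorter link leaves the number within the scatter. No measured data bear on why this is so.

Still open, from the compounds shown here alone, is whether the same shortening holds for the arrangement in compound 3. Going by these compounds, the effect of an amine or a longer chain as the link at this position also remains unknown.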